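Removing the trifluoromethyl group from compound 2

A few compounds are considered here, and "the series" means these few. Any claim that something is new, unique, unknown or untested is made for them only; others in the source may bear on it.

Compound 1 `C[C@H](NC(=O)c1nc(Br)c2cccnc2c1N[C@H]1CC[C@H](N)CC1)c1ccc(F)cc1`: > 10000 nM (a limit)
Compound 2 `N[C@H]1CC[C@H](Nc2c(C(=O)NCc3cccc(C(F)(F)F)c3)nc(Br)c3cccnc23)CC1`: 12000 nM

Going by the values given here, in a functional assay on HEY cells (Homo sapiens) for cytotoxicity, read by MTT assay, with a stated time of 72 h (on this read-out lower numbers stand for stronger inhibition and higher numbers for weaker inhibition), compound 2 gives 12000 nM, the only true number so far. Compound 1 gives > 10000 nM, which is a limit. Among the compounds with values here, the sole measured step, a step that the limit leaves unreadable from compound 1 to compound 2, has no readable size because of the limit of > 10000 nM in this assay, at which 1 of the 2 values shown sits.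

Compound 3 `N[C@H]1CC[C@H](Nc2c(C(=O)NCc3ccccc3)nc(Br)c3cccnc23)CC1` carries hydrogen in place of trifluoromethyl on an aromatic carbon, (hydrogen in place of trifluoromethyl on an aromatic carbon). No measured step sizes this change, so with compound 2 at 12000 nM as the only anchor, no shift beyond the scatter is expected. The expected step is no change at the digits printed from compound 2 to compound 3 (within the scatter). Compound 3 is estimated at 12000 nM, within an expected range of 5000 nM to 30000 nM.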

Compound 3, half-maximal inhibitory concentration: 8000 nM
Beside the measured number, compound 3's estimate is 1.5-fold (0.18 log units) above it, and the stated range covers the measured number.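

In this assay, going by these compounds alone, replacing trifluoromethyl with hydrogen on the benzyl ring gives a 1.5-fold lower number from compound 2 to compound 3 (0.18 log units; within the scatter), the first step here with a readable size, so at this place the two groups cannot be told apart. Changing the amide substituent to benzyl gives an at least 1.2-fold lower number from compound 1 to compound 3 (0.09 log units; that floor lies within the scatter), which is only a floor. The value of compound 1 is a limit: the limit of > 10000 nM in this assay, at which 1 of the 3 values shown sits.

Still open, from the compounds shown here alone, is whether an amine, a methoxy or a carboxylic acid at this place on the ring would move the number beyond the scatter.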